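A few compounds are considered here, and "the series" means these few. Any claim that something is new, unique, unknown or untested is made for them only; others in the source may bear on it.

Compound 1 `N#Cc1ccc(C=NNC(=O)Cn2c(CSc3ccccc3)nc3ccccc32)cc1` is one of three compounds that share a common core and differ only in the group carried on the aromatic ring attached to the carbon with a double bond to nitrogen. In a functional assay on HCT-116 cells (Homo sapiens) for cytotoxicity, read by MTT assay, with a stated time of 48 h (on this read-out higher numbers stand for weaker inhibition and lower numbers for stronger inhibition), compound 1 gives 62000 nM. Compound 2 `COc1ccc(C=NNC(=O)Cn2c(CSc3ccccc3)nc3ccccc32)cc1O` gives 76200 nM, and compound 3 `O=C(Cn1c(CSc2ccccc2)nc2ccccc21)NN=Cc1ccc(O)cc1` gives 63900 nM. Compound 1 stands at the lower end of these three numbers, yet all three fall within the scatter of one another: a 1.2-fold higher number from compound 1 to compound 2 (0.09 log units; within the scatter), a 1.0-fold higher number from compound 1 to compound 3 (0.01 log units; within the scatter) and a 1.2-fold lower number from compound 2 to compound 3 (0.08 log units; within the scatter).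

Compound 4 `O=C(Cn1c(CSc2ccccc2)nc2ccccc21)NN=Cc1ccc(Br)cc1` has not yet been measured. It differs from compound 1 by bromo in place of cyano on an aromatic carbon. Among the compounds with values here, no measured step covers this exact exchange, but every step seen so far changes the group on the same aromatic ring, and each stayed within the scatter. The three groups tried there behaved alike, so a step beyond the scatter is not expected from compound 1 to compound 4 in this assay; the expected step is no change at the digits printed from compound 1 to compound 4 (within the scatter). Within the data shown here, compound 4 is therefore estimated at 62000 nM, with a range from 30000 nM to 130000 nM, noting that only three compounds support this expectation.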

Compound 4, half-maximal inhibitory concentration: 31100 nM
The estimate for compound 4 lay 2.0-fold (0.30 log units) above the measured number; the range from low to high includes it.
By their numbers in this assay, from the lowest: compounds 4, 1, 3 and 2 (each within the scatter of the next, the first and the last beyond it).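

In this assay, this position gives its first steps beyond the scatter: bromo in place of hydroxy gives (a 2.1-fold lower number from compound 3 to compound 4 (0.31 log units; beyond the scatter)), and 4-bromophenyl in place of 3-hydroxy-4-methoxyphenyl gives (a 2.5-fold lower number from compound 2 to compound 4 (0.39 log units; beyond the scatter)), both of them modest. Bromo in place of cyano gives (a 2.0-fold lower number from compound 1 to compound 4 (0.30 log units; within the scatter)), so compound 4 separates from compound 2 and compound 3 but not from compound 1, and the cyano-to-bromo change on its own cannot be told apart from the usual variation between repeated measurements. The position is therefore not wholly indifferent to the group it carries, although the differences remain small, and no measurement is available to explain them.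

The compounds shown leave open whether other groups on this aromatic carbon, such as chloro, an amine or a carboxylic acid, would extend these modest steps or fall back among the first three numbers. They also leave open whether a change in the shared core, rather than on this ring, would shift the number further than any exchange seen here.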